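This account rests on a few compounds, and the source may have more. Where it says the series, first, only, none or still open, it means among the compounds named here.

Series notes. Of the compounds shown here, two have been measured in a functional assay on cells for antagonist activity at prostaglandin E2 receptor EP1 subtype (Rattus norvegicus), read by fluorescence and calcium flux, with a stated time of 60 s; a lower number here means a stronger inhibitor, a higher number a weaker inhibitor. Compound 1 `O=C(O)c1cccc(Cc2c(-c3ccc(Cl)cc3)nn3cc(Cl)ccc23)n1` gives 1100 nM, and compound 2 `O=C(O)c1cccc(Cc2c(C3CCCCC3)nn3cc(Cl)ccc23)n1` gives 1200 nM. Among the measured compounds shown here, compound 1 holds the lower of the two numbers, but its only neighbour is compound 2, and the step of a 1.1-fold higher number from compound 1 to compound 2 (0.04 log units; within the scatter) stays within the scatter, so the two cannot be told apart on these data.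

Compound 3 `O=C(O)c1cccc(Cc2c(N3CCCCCC3)nn3cc(Cl)ccc23)n1` has not yet been measured in this assay. It differs from compound 1 by azepan-1-yl in place of 4-chlorophenyl on an aromatic carbon. For the measured compounds named here, the only measured step at the same aromatic carbon is a 1.1-fold higher number from compound 1 to compound 2 (0.04 log units; within the scatter), where cyclohexyl took the place of 4-chlorophenyl without any movement beyond the scatter. Going by the values given here, no measured pair covers a ring joined through nitrogen at that carbon, so the entry of azepan-1-yl is an untested change, and the one step available is flat. Compound 3 is expected to show a step of a 1.4-fold higher number from compound 1 to compound 3 (0.13 log units; within the scatter) of modest size, with a wide range allowed for the untested group. The estimated value for compound 3 in this assay is 1500 nM, with a range from 500 nM to 5000 nM.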

Compound 3, half-maximal inhibitory concentration: 1400 nM
For compound 3 the middle estimate is 1.1-fold (0.03 log units) above the measured one; low and high end bracket the measured number.
By their numbers in this assay, from the lowest: compounds 1, 2 and 3 (each within the scatter of the next).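

In this assay, a ring joined through nitrogen at this aromatic carbon reads the same as the two rings joined through carbon: azepan-1-yl for 4-chlorophenyl gives a 1.3-fold higher number from compound 1 to compound 3 (0.10 log units; within the scatter) and azepan-1-yl for cyclohexyl gives a 1.2-fold higher number from compound 2 to compound 3 (0.07 log units; within the scatter) and neither step leaves the scatter. Among these three compounds, the position has now held a six-membered aromatic ring of carbon only, cyclohexyl and a seven-membered non-aromatic ring with a hetero atom and a hydrogen-bond acceptor, and no group is separated from another. No measurement at hand bears on why the three groups read alike.

The compounds shown leave open whether a much smaller group at this carbon, such as methyl or dimethylamino, or a ring such as morpholin-4-yl, would move the number beyond the scatter. They also leave open how much of the shared level depends on the rest of the core, for instance whether a primary amide in place of the carboxylic acid would change the reading.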